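Swapping the anilino group for a methylpiperidine

The compounds below may be only part of what the source reports. "The series", "measured", "known", "first", "only" and "open" are said of these compounds alone.

Of the compounds shown here, three with a shared core have been tested in a functional assay on NCI-H460 cells (Homo sapiens) for antiproliferative activity, read by CCK-8 assay, with a stated time of 72 h, tested at 2 uM; on this read-out higher numbers stand for a stronger effect at the one concentration tested and lower numbers for a weaker effect. Compound 1 `CC1CCN(c2nc(Cl)nc3c2ncn3Cc2ccc(/C=C/C(=O)Nc3ccccc3N)cc2)CC1` gives 8.24%, compound 2 `Nc1ccccc1NC(=O)c1ccc(Cn2cnc3c(Nc4ccccc4)nc(Cl)nc32)cc1` gives 42.7%, and compound 3 `Nc1ccccc1NC(=O)c1ccc(Cn2cnc3c(Nc4cccc(OC(F)(F)F)c4)nc(Cl)nc32)cc1` gives 47.7%, the highest of the three numbers, though its gap to compound 2 lies within the scatter while its gap to compound 1 lies beyond it. For the measured compounds named here, the only measured step, a number 5 percentage points higher from compound 2 to compound 3 (within the scatter), does not touch the group changed here. Compound 4 `CC1CCN(c2nc(Cl)nc3c2ncn3Cc2ccc(C(=O)Nc3ccccc3N)cc2)CC1` differs from compound 3 as follows: 4-methylpiperidin-1-yl in place of (3-(trifluoromethoxy)phenyl)amino on an aromatic carbon. Compound 1 also carries the 4-methylpiperidin-1-yl group, and its number stands far under that of compound 3, though the two differ elsewhere as well. A drop is therefore expected, a number 29.7 percentage points lower from compound 3 to compound 4 (beyond the scatter). Compound 4 is estimated at 18%, between 5% and 40%.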

Compound 4, a percentage reported as inhibition, at one concentration (the size of the read-out at that concentration, not a potency): 11.8%
The estimate for compound 4 lay 6.2 percentage points above the measured number, and the stated range covers the measured number.
By their numbers in this assay, from the lowest: compounds 1 and 4 (each within the scatter of the next); then compounds 2 and 3 (each within the scatter of the next).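

At this position on the shared core, the 4-methylpiperidin-1-yl group now has a direct reading in this assay: a number 35.9 percentage points lower from compound 3 to compound 4 (beyond the scatter), and a number 30.9 percentage points lower from compound 2 to compound 4 (beyond the scatter). Shortening the side chain by removing the ethenyl link, by contrast, gives a number 3.6 percentage points higher from compound 1 to compound 4 (within the scatter). Nothing available gives a reason for the loss at this position.

Still open, going by these compounds, is whether the loss follows the aromatic ring or the nitrogen's hydrogen. Cyclohexylamino would keep that hydrogen without the aromatic ring, and N-methylanilino would keep the aromatic ring without that hydrogen.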